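A few compounds are considered here, and "the series" means these few. Any claim that something is new, unique, unknown or untested is made for them only; others in the source may bear on it.

Compound 1 `O=C(NCC1CCN(CCCS(=O)(=O)N2CCN(c3ccccn3)CC2)CC1)c1cccc2c1OCCO2` gives 0.251 nM in an assay on isolated protein for inhibition of 5-hydroxytryptamine receptor 4 (Homo sapiens); on this read-out higher numbers stand for weaker inhibition and lower numbers for stronger inhibition. Compound 2 `O=C(NCC1CCN(CCCS(=O)(=O)N2CCN(Cc3cccnc3)CC2)CC1)c1cccc2c1OCCO2` gives 0.159 nM in this assay. Compound 3 `CS(=O)(=O)N1CCN(S(=O)(=O)CCCN2CCC(CNC(=O)c3cccc4c3OCCO4)CC2)CC1` gives 0.316 nM in this assay.

All three share a core and differ only in the group on the distal nitrogen of the piperazine that sits on the sulfonyl sulfur. The three numbers lie close together: the step of a 1.6-fold lower number from compound 1 to compound 2 (0.20 log units; within the scatter) and the step of a 1.3-fold higher number from compound 1 to compound 3 (0.10 log units; within the scatter) are both within the scatter, and the step of a 2.0-fold higher number from compound 2 to compound 3 (0.30 log units; within the scatter) also stays within the scatter. Compound 3 therefore cannot be separated from compound 1 or compound 2 on these numbers.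

Compound 4 `CCCC1CCN(S(=O)(=O)CCCN2CCC(CNC(=O)c3cccc4c3OCCO4)CC2)CC1` has not yet been measured in this assay. It differs from compound 3 as follows: 4-propylpiperidin-1-yl in place of 4-(methylsulfonyl)piperazin-1-yl on a sulfonyl sulfur. The measured steps that bear on this change are those around the same nitrogen, and none of them moved the number beyond the scatter. The change to compound 4 is wider, as the whole piperazine with its methylsulfonyl gives way to a 4-propylpiperidin-1-yl, so the expectation is held with less confidence. Compound 4 is expected to give 0.5 nM, a step of a 1.6-fold higher number from compound 3 to compound 4 (0.20 log units; within the scatter), within a range from 0.15 nM to 2 nM.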

Compound 4, inhibition constant: 0.0631 nM
Compound 4: the middle estimate sits 7.9-fold (0.90 log units) above what was measured, and the stated range ends above it.
By their numbers in this assay, from the lowest: compound 4; then compounds 2, 1 and 3 (each within the scatter of the next).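

The earlier changes at this position altered only the group on the distal piperazine nitrogen, and all of them stayed within the scatter. Replacing the whole 4-(methylsulfonyl)piperazin-1-yl on the sulfonyl sulfur does move the number in this assay beyond the scatter (a 5.0-fold lower number from compound 3 to compound 4 (0.70 log units; beyond the scatter)), and replacing the 4-(pyridin-2-yl)piperazin-1-yl gives a similar modest step (a 4.0-fold lower number from compound 1 to compound 4 (0.60 log units; beyond the scatter)), so this position is not as insensitive to change as the first three compounds suggested. The entering 4-propylpiperidin-1-yl has 8 carbon atoms, 1 nitrogen and 0 hydrogen-bond acceptors, against 2 acceptors in the 4-(methylsulfonyl)piperazin-1-yl, but no evidence at hand accounts for the step.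

The compounds shown do not separate the contribution of the propyl chain from that of exchanging the piperazine for a piperidine, a question that an unsubstituted piperidin-1-yl or a 4-propylpiperazin-1-yl would address. Going by these compounds, it also remains open how the number responds to a shorter or longer chain on the piperidine, or to a hydroxyl or an amine at the end of that chain.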